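A Third Aryl Variant on the Aromatic Ring Nitrogen

The source may report more compounds than this note shows. Statements on the series, on what has been measured and on what is new or still open speak of the compounds shown alone.

In a functional assay on PC-9 cells (Homo sapiens) for inhibition, read by MTT assay, with a stated time of 48 h, tested at 10 uM (on this read-out lower numbers stand for less inhibition and higher numbers for more inhibition at the one concentration tested (going by the name of the read-out)), compound 2 `COc1cc(NC(=O)Nc2cc(Nc3cccc(C(C)(C)C)c3)ncn2)cc(OC)c1` gives 68%, the higher of the two numbers shown, though its companion compound 1 `COc1cc(NC(=O)Nc2cc(Nc3ccc(C)c(C)c3)ncn2)cc(OC)c1` gives 66% and the step of a number 2 percentage points higher from compound 1 to compound 2 (within the scatter) stays within the scatter. Compound 3 `COc1cc(NC(=O)Nc2cc(Nc3ccc(F)c(Cl)c3)ncn2)cc(OC)c1` differs from compound 2 by 3-chloro-4-fluorophenyl in place of 3-(tert-butyl)phenyl on a nitrogen on an aromatic ring. For the measured compounds named here, the only step that bears on this exchange of the aryl group is the one from compound 1 to compound 2, and it was small. Compound 3 is therefore expected to show a number 3 percentage points lower from compound 2 to compound 3 (within the scatter), nothing beyond the scatter. The value of compound 3 is estimated at 65%, within 50% to 80%.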

Compound 3, a percentage reported as inhibition, at one concentration (the size of the read-out at that concentration, not a potency): 77.5%
Beside the measured number, compound 3's estimate is 12.5 percentage points below it, and the stated range covers the measured number.
By their numbers in this assay, from the lowest: compounds 1, 2 and 3 (each within the scatter of the next, the first and the last beyond it).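

In this assay, for the compounds shown here, the position on a nitrogen on an aromatic ring now yields a step beyond the scatter for the first time: 3-chloro-4-fluorophenyl in place of 3,4-dimethylphenyl gives a number 11.5 percentage points higher from compound 1 to compound 3 (beyond the scatter) and so separates these two aryl groups. In place of 3-(tert-butyl)phenyl the same group gives a number 9.5 percentage points higher from compound 2 to compound 3 (within the scatter) and no such separation. Nothing measured here explains this difference between the aryl groups. The compounds shown leave open what an aryl group carrying an amine or a carboxylic acid, or a longer alkyl chain in place of the aryl ring, would give at this nitrogen.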